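Swapping the Pentyl Chain for Bromine on the Aryl Ring

The source may report more compounds than this note shows. Statements on the series, on what has been measured and on what is new or still open speak of the compounds shown alone.

Compound 1, `O=C1O[C@H]([C@@H](O)Cn2cc(-c3cc(F)cc(F)c3)nn2)C(OCc2ccccc2)=C1OCc1ccccc1`: in a functional assay on SW-620 cells (Homo sapiens) for antiproliferative activity, read by MTT assay, with a stated time of 72 h (on this read-out lower numbers stand for stronger inhibition and higher numbers for weaker inhibition), compound 1 reaches only the assay limit of > 100000 nM.
Compound 2, `COc1ccc(-c2cn(C[C@H](O)[C@H]3OC(=O)C(OCc4ccccc4)=C3OCc3ccccc3)nn2)cc1`: in this assay compound 2 gives 58200 nM.
Compound 3, `CCCCCc1ccc(-c2cn(C[C@H](O)[C@H]3OC(=O)C(OCc4ccccc4)=C3OCc3ccccc3)nn2)cc1`: in this assay compound 3 gives 12200 nM.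

Compound 3 holds the lowest of the two numbers measured in this assay. Going by these compounds, the nearest measured value is separated from it by the step of a 4.8-fold lower number from compound 2 to compound 3 (0.68 log units; beyond the scatter), and the step of an at least 8.1-fold lower number from compound 1 to compound 3 (0.91 log units; beyond the scatter) is bounded by the limit (the limit of > 100000 nM in this assay, at which 1 of the 3 values shown sits), so its true size is unknown.

Compound 4, `O=C1O[C@H]([C@@H](O)Cn2cc(-c3ccc(Br)cc3)nn2)C(OCc2ccccc2)=C1OCc1ccccc1`, has not yet been measured. It differs from compound 3 in one place: bromo in place of pentyl on an aromatic carbon. For the measured compounds named here, two measured steps bear on this change, both altering the group on the same aromatic carbon: a 4.8-fold lower number from compound 2 to compound 3 (0.68 log units; beyond the scatter) and an at least 8.1-fold lower number from compound 1 to compound 3 (0.91 log units; beyond the scatter). Both show that the pentyl group goes with the lowest number seen, and that smaller groups at that place give higher numbers. Bromo, a single heavy atom, is therefore expected to move the number upward by a modest amount, estimated as a 2.5-fold higher number from compound 3 to compound 4 (0.39 log units; beyond the scatter). For compound 4 the estimate in this assay is 30000 nM, within a range of 12000 nM to 100000 nM.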

Compound 4, half-maximal inhibitory concentration: 3760 nM
Estimate against measurement, compound 4: 8.0-fold (0.90 log units) above, outside the stated range (below it).
By their numbers in this assay, from the lowest: compound 4; then compound 3; then compound 2. At a limit, above all of these: compound 1.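

In this assay, for the compounds shown here, compound 4 breaks the trend suggested by the earlier compounds, in which the larger pentyl group held the lowest number: bromo, with fewer heavy atoms than pentyl, gives a 3.2-fold lower number from compound 3 to compound 4 (0.51 log units; beyond the scatter). Compared with methoxy on the same aromatic carbon, bromo gives a 15-fold lower number from compound 2 to compound 4 (1.19 log units; beyond the scatter), so among compounds 2, 3 and 4 the order of the numbers does not follow the heavy-atom count of the group, and compound 2 and compound 4 sit at the two ends of that order. Compound 1 sits at a limit, so an at least 26-fold lower number from compound 1 to compound 4 (1.42 log units; beyond the scatter) is only a floor and the true size of this step is unknown: the limit of > 100000 nM in this assay, at which 1 of the 4 values shown sits.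

The compounds shown leave open whether the low number in compound 4 is particular to bromo or would also appear with chloro or iodo on the same aromatic carbon of the 4-substituted phenyl ring. They also leave open where an amine, a carboxylic acid or a chain longer than pentyl would fall in this order.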